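This account rests on a few compounds, and the source may have more. Where it says the series, first, only, none or still open, it means among the compounds named here.

Measured compounds in an assay on isolated protein for inhibition of Gonadotropin-releasing hormone receptor (Rattus norvegicus); a higher number here means a weaker inhibitor, a lower number a stronger inhibitor:
Compound 1 `CC(C)n1c(SCc2ccccc2Cl)nc2cc(NC(=O)C3CC3)ccc21` gives > 10000 nM, which is a limit of the assay.
Compound 2 `COc1ccc(C#N)cc1CSc1nc2cc(NC(=O)C3CC3)ccc2n1C(C)C` gives > 10000 nM, also a limit of the assay.
Compound 3 `COc1ccc([N+](=O)[O-])cc1CSc1nc2cc(NC(=O)NC(C)(C)C)ccc2n1C1CC1` gives 860 nM.

For the measured compounds named here, compound 3 stands on the only actual number in this set; the other two values are limits, and the limit of > 10000 nM in this assay, at which 2 of the 3 values shown sit, is where compounds 1 and 2 sit. The step that the two limits leave unreadable from compound 1 to compound 2 runs between two limits and has no readable size.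

Compound 4 `CCn1c(SCc2cc([N+](=O)[O-])ccc2OC)nc2cc(NC(=O)NC(C)(C)C)ccc21` differs from compound 3 in one place: ethyl in place of cyclopropyl on an aromatic nitrogen. Going by the values given here, none of the measured steps touches the group on the aromatic nitrogen. Compounds 1 and 2 carry isopropyl there, but they also differ from compound 3 in the amide and in the aryl group on the saturated chain carbon bound to a sulfur, and their two limits show only that both fall beyond the range of this assay. Among the compounds with values here, with no measured step bearing on this change, the step from compound 3 to compound 4 is expected to be small, a 1.4-fold higher number from compound 3 to compound 4 (0.14 log units; within the scatter), within or near the scatter, with no direction favoured. Compound 4 is thus estimated at 1200 nM in this assay, with a range from 400 nM to 4000 nM.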

Compound 4, half-maximal inhibitory concentration: 170 nM
Compound 4: the middle estimate sits 7.1-fold (0.85 log units) above what was measured, and the stated range ends above it.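

The group on the aromatic nitrogen turns out to matter in this assay: with everything else in the molecule unchanged, ethyl in place of cyclopropyl gives a 5.1-fold lower number from compound 3 to compound 4 (0.70 log units; beyond the scatter), a change that lies beyond the usual scatter. For the compounds shown here, this position, which no earlier step touched, is therefore not neutral, and within this one pair the ethyl group, which has no ring, gives the stronger inhibitor. Nothing measured in this set accounts for the size or direction of this step.

From the compounds shown here alone, this is a single pair that shares the tert-butyl urea and the 2-methoxy-5-nitrophenyl group, so it remains open whether the same change would have a similar effect alongside the cyclopropyl amide of compounds 1 and 2, which carry isopropyl on this nitrogen, differ from compound 3 in more than one place and each stand at a limit of the assay. Also open, going by these compounds, is how a methyl group, a longer chain such as n-propyl, or a hydroxyethyl chain on this nitrogen would compare with ethyl.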